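Replacing the pyridyl arm on the pyrazole nitrogen with chlorophenyl

The source may hold more compounds than are shown below. What is called first, only, known or untested is meant among the compounds shown, and "the series" means these compounds.

Compound 1 `CCCC(Oc1cnn(-c2ccc(C(F)(F)F)cn2)c1)c1ccc(C(=O)NCCC(=O)O)cc1` is the reference point of this small set. In a functional assay on cells for antagonist activity at Glucagon receptor (Homo sapiens), read by cAMP accumulation (a lower number here means a stronger inhibitor, a higher number a weaker inhibitor), compound 1 gives 16400 nM, and this is the only plain number shown. Compound 2 `CCCC(Oc1cnn(-c2ccc(OC)cc2)c1)c1ccc(C(=O)NCCC(=O)O)cc1` carries a 4-methoxyphenyl in place of the 5-(trifluoromethyl)pyridin-2-yl on the aromatic nitrogen. In this assay compound 2 reaches only the limit of the assay, > 21300 nM, which is a limit and not a number (the limit of > 21300 nM in this assay, at which 1 of the 2 values shown sits). The step of an at least 1.2-fold higher number from compound 1 to compound 2 (0.11 log units; that floor lies within the scatter) is therefore a floor that lies within the scatter, so it points to no real change.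

Compound 3 `CCCC(Oc1cnn(-c2ccc(Cl)cc2)c1)c1ccc(C(=O)NCCC(=O)O)cc1` is not yet measured. It differs from compound 1 by 4-chlorophenyl in place of 5-(trifluoromethyl)pyridin-2-yl on an aromatic nitrogen. Among the measured compounds shown here, the only measured step that bears on this change is the one from compound 1 to compound 2, and that step was too small to show a direction. With a second exchange of the same arm on the shared core, no step beyond the scatter is expected in this assay, though a limit is again possible. The step expected is a 1.2-fold higher number from compound 1 to compound 3 (0.09 log units; within the scatter). Compound 3 is accordingly estimated at 20000 nM, within 7000 nM to 60000 nM.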

Compound 3, antagonist equilibrium constant: > 7520 nM
Compound 3 gave a limit, no number; the forecaster's own chance of this, stated with the estimate: 40%; the middle value is on the limit's open side.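

In this assay compound 3 gives > 7520 nM, which is a limit and not a number. The steps to compound 3 from compound 1 and from compound 2 therefore cannot be read: the limit of > 7520 nM in this assay, at which 1 of the 3 values shown sits. The compounds shown leave open whether 4-chlorophenyl or 4-methoxyphenyl in place of 5-(trifluoromethyl)pyridin-2-yl changes the number at all in this assay.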